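This account rests on a few compounds, and the source may have more. Where it says the series, first, only, none or still open, it means among the compounds named here.

Compound 1, `O=C1/C(=C/c2ccc(Br)cc2)Cc2ccccc21`: 284000 nM in a functional assay on CCRF-CEM cells (Homo sapiens) for inhibition; on this read-out lower numbers stand for stronger inhibition and higher numbers for weaker inhibition.
Compound 2, `Cc1ccc(/C=C2\Cc3ccccc3C2=O)cc1`: 67100 nM in this assay.
Compound 3, `O=C1/C(=C/c2cccc(Br)c2)CCCc2ccccc21`: 8900 nM in this assay.

Compounds 1 and 2 share one core and differ in a single place: methyl in place of bromo on an aromatic carbon. That change made a 4.2-fold lower number from compound 1 to compound 2 (0.63 log units; beyond the scatter). Compound 3 carries a different core, and it gives the lowest number of the three; how the core of compound 3 differs from the core of compound 1 is not broken down here. Compound 4, `Cc1cccc(/C=C2\CCCc3ccccc3C2=O)c1`, is still to be measured in this assay. It differs from compound 3 by methyl in place of bromo on an aromatic carbon. This is the same kind of change as from compound 1 to compound 2, though the surroundings differ: in compound 1 the exchanged group sits para to a large group, in compound 3 meta to a large group. Because a 4.2-fold lower number from compound 1 to compound 2 (0.63 log units; beyond the scatter), a step of similar size is expected here: a 3.6-fold lower number from compound 3 to compound 4 (0.55 log units; beyond the scatter). Compound 4 is expected to give 2500 nM in this assay, most likely between 900 nM and 8000 nM.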

Compound 4, half-maximal inhibitory concentration: 15800 nM
The estimate for compound 4 lay 6.3-fold (0.80 log units) below the measured number, and the stated range ends below it.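

On the core of compound 3, the exchange of bromo for methyl gave a 1.8-fold higher number from compound 3 to compound 4 (0.25 log units; within the scatter) in this assay, so on this core the two groups cannot be told apart. The change therefore did not carry over from the core of compound 1 with the same effect: the same change on two cores in this assay, a 4.2-fold lower number (0.63 log units; beyond the scatter) from compound 1 to compound 2 and a 1.8-fold higher number (0.25 log units; within the scatter) from compound 3 to compound 4, 7.5-fold (0.88 log units) apart, beyond the scatter of two such steps. This does not show what sets the two steps apart, as the pairs differ both in their core and in where the exchanged group sits, and two pairs give no rule for the series.

The compounds shown leave open how the two cores compare when they carry the same group in the same place. From the compounds shown here alone, it also remains open how a chloro, a methoxy or an amine group would behave at this place on either core.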